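Swapping the Ketone Aryl Group: Indolyl Replaces Fluorophenyl

The source may hold more compounds than are shown below. What is called first, only, known or untested is meant among the compounds shown, and "the series" means these compounds.

Three compounds sharing one core were tested in a functional assay on MCF7 cells (Homo sapiens) for antiproliferative activity, read by XTT assay, with a stated time of 72 h; a lower number here means a stronger inhibitor, a higher number a weaker inhibitor. Compound 1 `COc1ccc(-c2cc3ccccc3nc2/C=C/C(=O)c2ccc(F)cc2)cc1` gives 5450 nM, the second highest of the three numbers. Compound 2 `COc1ccc(C(=O)/C=C/c2nc3ccccc3cc2-c2ccc(OC)cc2)cc1` gives 7380 nM, and a 1.4-fold higher number from compound 1 to compound 2 (0.13 log units; within the scatter). Compound 3 `COc1ccc(-c2cc3ccccc3nc2/C=C/C(=O)c2ccccn2)cc1` gives 810 nM; here a 6.7-fold lower number from compound 1 to compound 3 (0.83 log units; beyond the scatter), and a 9.1-fold lower number from compound 2 to compound 3 (0.96 log units; beyond the scatter).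

Compound 4 `COc1ccc(-c2cc3ccccc3nc2/C=C/C(=O)c2c[nH]c3ccccc23)cc1` is not yet measured. It differs from compound 1 in one place: 1H-indol-3-yl in place of 4-fluorophenyl on a carbonyl carbon. Going by the values given here, the step that bears on it is the one to compound 3, where pyridin-2-yl replaced 4-fluorophenyl on the carbonyl carbon and gave a 6.7-fold lower number from compound 1 to compound 3 (0.83 log units; beyond the scatter). The step to compound 2 touched only a substituent and stayed within the scatter. A modest lowering is therefore expected for compound 4: a 2.5-fold lower number from compound 1 to compound 4 (0.39 log units; beyond the scatter). Compound 4 is estimated at 2200 nM, within 700 nM to 7000 nM.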

Compound 4, half-maximal inhibitory concentration: > 10000 nM
Compound 4: no number, only a limit (the forecaster's own chance of this, stated with the estimate: 2%); middle value at least 4.5-fold (0.65 log units) from the limit.
By their numbers in this assay, from the lowest: compound 3; then compounds 1 and 2 (each within the scatter of the next). At a limit, above all of these: compound 4.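

In this assay compound 4 gives > 10000 nM, which is a limit and not a number. This shows that changing the ring on the carbonyl carbon does not always lower the number, as 1H-indol-3-yl in place of pyridin-2-yl gives an at least 12-fold higher number from compound 3 to compound 4 (1.09 log units; beyond the scatter). The other two steps are only floors, an at least 1.8-fold higher number from compound 1 to compound 4 (0.26 log units; that floor lies within the scatter) and an at least 1.3-fold higher number from compound 2 to compound 4 (0.13 log units; that floor lies within the scatter), so how far compound 4 truly lies from these two stays unsettled.

Still open, from the compounds shown here alone, is how a plain phenyl or a pyridin-4-yl on this carbonyl carbon would behave. Going by these compounds, whether a simple amine there would follow compound 3 or compound 4 is also open.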